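Swapping the pyridinylmethyl group for isopropyl on the shared core

The compounds below may be only part of what the source reports. "The series", "measured", "known", "first", "only" and "open" are said of these compounds alone.

Compound 1 `CCOC(=O)c1ccc(-c2nn(Cc3ccccn3)c3ccccc23)cc1` gives > 10000 nM in a functional assay on cells (Platelet, Homo sapiens) for inhibition (a lower number here means a stronger inhibitor, a higher number a weaker inhibitor), which is a limit and not a number. Compound 2 `CCOC(=O)c1ccc(-c2nn(Cc3cccnc3)c3ccccc23)cc1` gives > 10000 nM, again only a limit. Among the measured compounds shown here, the series so far stands at the limit of > 10000 nM in this assay, at which 2 of the 2 values shown sit. For the measured compounds named here, the one measured step, a step that the two limits leave unreadable from compound 1 to compound 2, offers no size to carry forward. Compound 3 `CCOC(=O)c1ccc(-c2nn(C(C)C)c3ccccc23)cc1` brings (isopropyl in place of (pyridin-3-yl)methyl on an aromatic nitrogen). With no readable step to lean on, no clear change in this assay is expected, and the estimated step is a step that the limit leaves unreadable from compound 2 to compound 3. Compound 3 is estimated at 12000 nM, with an expected range of 3000 nM to 40000 nM.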

Compound 3, half-maximal inhibitory concentration: > 10000 nM
Compound 3 gave a limit, no number; the forecaster's own chance of this, stated with the estimate: 75%; the middle value lies beyond the limit too.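

In this assay, among the compounds shown here, compound 3 gives > 10000 nM, a limit and not a number, and no step among compound 1, compound 2 and compound 3 can be read. The compounds shown leave open whether any group on that aromatic nitrogen of the shared core gives a measurable inhibition.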